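Taking the ethoxy group off compound 2

This account rests on a few compounds, and the source may have more. Where it says the series, first, only, none or still open, it means among the compounds named here.

Compound 1 `Clc1cccc2sc(Nc3nc4ccccc4s3)nc12`: > 50000 nM
Compound 2 `CCOc1ccc2nc(Nc3nc4ccccc4s3)sc2c1`: > 50000 nM

In a functional assay on U-937 cells (Homo sapiens) for cytotoxicity, read by MTT assay, with a stated time of 48 h (on this read-out lower numbers stand for stronger inhibition and higher numbers for weaker inhibition), compound 2 stands at > 50000 nM, which is a limit of the assay and not a number. Compound 1 gives > 50000 nM, also a limit. Among the compounds with values here, the series so far is the limit of > 50000 nM in this assay, at which 2 of the 2 values shown sit, so neither compound has a number that could rank it.

Compound 3 `c1ccc2sc(Nc3nc4ccccc4s3)nc2c1` carries hydrogen in place of ethoxy on an aromatic carbon. Within the data shown here, no measured step gives the size of this change. In this assay, no step beyond the scatter is expected in either direction, and another limit is the likelier report. The expected change is a number no higher from compound 2 to compound 3 (the limit leaves the size open). Compound 3 is estimated at 50000 nM, with an expected range from 20000 nM to 100000 nM.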

Compound 3, half-maximal inhibitory concentration: 40000 nM
Compound 3: middle estimate off by 1.3-fold (0.10 log units), on the high side; the measured number falls inside the stated range.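

In this assay, within the data shown here, compound 3 gives 40000 nM, the first true number, so the core with hydrogen on this aromatic carbon can now be placed on the scale. Hydrogen in place of ethoxy gives an at least 1.2-fold lower number from compound 2 to compound 3 (0.09 log units; that floor lies within the scatter), and hydrogen in place of chloro gives an at least 1.2-fold lower number from compound 1 to compound 3 (0.09 log units; that floor lies within the scatter); neither step shows a change beyond the scatter. Each step starts from a limit and not from a number, and limits still make up most of the series: the limit of > 50000 nM in this assay, at which 2 of the 3 values shown sit.

Among the compounds shown, only the one with hydrogen carries a number, so the true size of both steps stays open. Also open, going by these compounds, is whether an amine, a carboxylic acid or a longer chain on this aromatic carbon would give a number clearly apart from that of compound 3.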